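Swapping the Aromatic Group of Compound 2

The source may hold more compounds than are shown below. What is called first, only, known or untested is meant among the compounds shown, and "the series" means these compounds.

Compound 1 `CC1=CC[C@H]2[C@H](CC[C@]2(C)O)C(C)(C)[C@@H]1CC[C@H]1[C@]2(C)CC[C@H](OC(=O)c3ccc([N+](=O)[O-])cc3)C(C)(C)O[C@H]2CC[C@@]1(C)O` gives 8900 nM in a functional assay on MDA-MB-231 cells (Homo sapiens) for antiproliferative activity, read by MTT assay, with a stated time of 72 h; on this read-out higher numbers stand for weaker inhibition and lower numbers for stronger inhibition
Compound 2 `COc1ccc(C(=O)O[C@H]2CC[C@]3(C)[C@H](CC[C@@](C)(O)[C@H]3CC[C@@H]3C(C)=CC[C@H]4[C@H](CC[C@]4(C)O)C3(C)C)OC2(C)C)cc1` gives 30600 nM in this assay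

Among the compounds with values here, of these two, compound 2 has the higher number at 30600 nM and is therefore the weaker inhibitor, with compound 1 as its only neighbour. The next structure, compound 3 `CC1=CC[C@H]2[C@H](CC[C@]2(C)O)C(C)(C)[C@@H]1CC[C@H]1[C@]2(C)CC[C@H](OC(=O)c3ccc(Cl)c(Cl)c3)C(C)(C)O[C@H]2CC[C@@]1(C)O`, keeps the shared core and changes one group 3,4-dichlorophenyl in place of 4-methoxyphenyl on a carbonyl carbon with 3,4-dichlorophenyl in place of 4-methoxyphenyl on a carbonyl carbon.

Within the data shown here, only one measured step bears on this change. With methoxy in place of nitro on an aromatic carbon, the data show a 3.4-fold higher number from compound 1 to compound 2 (0.54 log units; beyond the scatter) and this modest step shows that the number can move when this aromatic group is altered. Among the measured compounds shown here, no measured compound carries chlorine, so one step gives only a rough guide.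

A modest step of similar size is expected, and the estimate is a 2.6-fold lower number from compound 2 to compound 3 (0.41 log units; beyond the scatter) in this assay as a result. For the measured compounds named here, the expected direction rests on compound 1, which at 8900 nM is the only measured compound below compound 2. For compound 3 the estimated value is 12000 nM with an expected range from 4500 nM to 32000 nM as its span.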

Compound 3, half-maximal inhibitory concentration: 8100 nM
For compound 3 the middle estimate is 1.5-fold (0.17 log units) above the measured one, within the range that was stated.
By their numbers in this assay, from the lowest: compounds 3 and 1 (each within the scatter of the next); then compound 2.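

In this assay, 3,4-dichlorophenyl in place of 4-methoxyphenyl on the carbonyl carbon gives a 3.8-fold lower number from compound 2 to compound 3 (0.58 log units; beyond the scatter), so a second replacement for the 4-methoxyphenyl group, one with chlorine rather than nitro, also ends well clear of compound 2. Set against each other, the two replacements give a 1.1-fold lower number from compound 1 to compound 3 (0.04 log units; within the scatter), which means that the 4-nitrophenyl and 3,4-dichlorophenyl groups cannot be told apart on this read-out, and among the three compounds only the 4-methoxyphenyl group of compound 2 stands apart from the others. Nothing measured alongside these numbers gives a reason for the gap between compound 2 and the other two compounds, so the data record the size of the change but no explanation for it.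

The compounds shown leave open whether both chlorine atoms are needed, since a 4-chlorophenyl group would separate the effect of one chlorine from that of the pair. They also leave open how this position would respond to an unsubstituted phenyl ring, to a phenyl ring carrying an amine or a carboxylic acid, or to a simple acetyl group with no ring at all.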